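From a Branched Side Group to Cyclopropyl

The compounds below may be only part of what the source reports. "The series", "measured", "known", "first", "only" and "open" are said of these compounds alone.

In a functional assay on MCF7 cells (Homo sapiens) for inhibition, read by fluorescence, with a stated time of 72 h (on this read-out higher numbers stand for weaker inhibition and lower numbers for stronger inhibition), compound 1 (`CC(C)n1cnc2c(NC(=N)N)nc(NCCCCCCO)nc21`) gives 5200 nM and compound 2 (`CC(C)[C@@H](CO)Nc1nc(NC(=N)N)c2ncn(C(C)C)c2n1`) gives 2100 nM, the lower of the two numbers. Compound 3 (`CC(C)n1cnc2c(NC(=N)N)nc(NC3CC3)nc21`) departs from compound 2 by cyclopropyl in place of 1-(hydroxymethyl)-2-methylpropyl on a nitrogen on an aromatic ring, with cyclopropyl in place of 1-(hydroxymethyl)-2-methylpropyl on a nitrogen on an aromatic ring. Among the compounds with values here, the only measured step at that nitrogen, a 2.5-fold lower number from compound 1 to compound 2 (0.39 log units; beyond the scatter), is modest, and neither compound carries a ring there. A step of similar size is therefore expected in this assay, tentatively toward a higher number, as an estimated 2.4-fold higher number from compound 2 to compound 3 (0.38 log units; beyond the scatter). For compound 3 the estimate is 5000 nM, with an expected range of 1500 nM to 17000 nM.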

Compound 3, half-maximal inhibitory concentration: 5400 nM
Compound 3: middle estimate off by 1.1-fold (0.03 log units), on the low side; the measured number falls inside the stated range.
By their numbers in this assay, from the lowest: compound 2; then compounds 1 and 3 (each within the scatter of the next).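

In this assay, cyclopropyl brings the first ring to this nitrogen, and replacing the branched group gives a 2.6-fold higher number from compound 2 to compound 3 (0.41 log units; beyond the scatter), so the lower number of compound 2 does not carry over to this smaller group. Against the unbranched chain, the change gives a 1.0-fold higher number from compound 1 to compound 3 (0.02 log units; within the scatter), leaving compound 2 alone apart from the other two. No evidence on hand bears on this result. From the compounds shown here alone, it remains open how a cyclohexyl ring or an aminoalkyl chain on this nitrogen would read. The compounds shown also leave open whether the hydroxymethyl or the branching in compound 2 accounts for its lower number.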